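Swapping Fluoro for Methyl on a Benzoyl Group

This account rests on a few compounds, and the source may have more. Where it says the series, first, only, none or still open, it means among the compounds named here.

Two compounds share one core and differ only in the group attached to the carbonyl carbon. Compound 1 `O=C(c1cccnc1)c1cc2c(-c3cccnc3)nn(-c3ccccc3)c2[nH]c1=O` carries a pyridin-3-yl there, and in a functional assay on HepG2 cells (Homo sapiens) for cytotoxicity, read by sulforhodamine B assay (a higher number here means a weaker inhibitor, a lower number a stronger inhibitor), compound 1 gives 11 ug/mL. Compound 2 `O=C(c1ccc(F)cc1)c1cc2c(-c3cccnc3)nn(-c3ccccc3)c2[nH]c1=O` carries a 4-fluorophenyl instead, and in this assay compound 2 gives 7.8 ug/mL. That is the lowest of the two numbers, yet the step of a 1.4-fold lower number from compound 1 to compound 2 (0.15 log units; within the scatter) lies within the scatter, so the two compounds cannot be told apart on these data.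

Compound 3 `Cc1ccc(C(=O)c2cc3c(-c4cccnc4)nn(-c4ccccc4)c3[nH]c2=O)cc1` is not yet measured. It differs from compound 2 by methyl in place of fluoro on an aromatic carbon, the fluoro leaving and a methyl entering on an aromatic carbon of a six-membered aromatic ring of carbon only, para to a large group. Going by the values given here, no measured step touches this exact exchange; the only step at hand, from compound 1 to compound 2, replaced the whole ring on the carbonyl and moved the number little. A change of a single atom on that ring is therefore expected to stay within the scatter as well, with no clear direction, giving an expected step of a 1.0-fold higher number from compound 2 to compound 3 (0.01 log units; within the scatter). Compound 3 is estimated at 8 ug/mL in this assay, with a range from 4 ug/mL to 16 ug/mL.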

Compound 3, half-maximal inhibitory concentration: 8.85 ug/mL
Compound 3: the middle estimate sits 1.1-fold (0.04 log units) below what was measured; the measured number falls inside the stated range.
By their numbers in this assay, from the lowest: compounds 2, 3 and 1 (each within the scatter of the next).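

In this assay, going by these compounds alone, the exchange of fluoro for methyl gives a small step (a 1.1-fold higher number from compound 2 to compound 3 (0.05 log units; within the scatter)), the first measured change of a single group on this ring, on an aromatic carbon para to a large group, and it cannot be told apart from the ordinary spread of repeated measurements. The comparison with the pyridin-3-yl compound reads the same way (a 1.2-fold lower number from compound 1 to compound 3 (0.09 log units; within the scatter)), so on these numbers 4-methylphenyl, like 4-fluorophenyl, cannot be separated from pyridin-3-yl on the carbonyl carbon, and this position has so far given no step beyond the scatter. Nothing available here offers an explanation for these three compounds reading alike.

Still open, from the compounds shown here alone, is whether a group quite unlike fluoro and methyl in that same place, such as an amine, a carboxylic acid or a longer chain, would give a step that rises clearly above the scatter. Also open, going by these compounds, is whether changes elsewhere on the shared core, rather than on this ring, would move the number in a way that can be read.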